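The source may hold more compounds than are shown below. What is called first, only, known or untested is meant among the compounds shown, and "the series" means these compounds.

Values so far in an ADME assay on MRC5 cells (Homo sapiens) for inhibition, read by MTT assay, with a stated time of 72 h (a lower number here means a stronger inhibitor, a higher number a weaker inhibitor), are these:
- Compound 1 `O=C(OCCCCCCCCO)OCCc1ccc(O)c(O)c1` gives > 50000 nM as a limit of the assay, not a number
- Compound 2 `CCCCCCCCOC(=O)OCCc1ccc(O)c(O)c1` gives 37900 nM
- Compound 3 `CCCCCCCCCCCCCCCCOC(=O)OCCc1ccc(O)c(O)c1` gives "not determined" (no result reported)

Compound 3 therefore offers no number to start from. The change leading to compound 4 `CCCCCCCCCOC(=O)OCCc1ccc(O)c(O)c1` is hydrogen in place of heptyl on a saturated chain carbon (in detail (hydrogen in place of heptyl on a saturated chain carbon, nine bonds along the chain from an oxygen next to a carbonyl group)). Going by the values given here, only one measured step bears on this, and only loosely (an at least 1.3-fold lower number from compound 1 to compound 2 (0.12 log units; that floor lies within the scatter)). That step swaps hydroxy for hydrogen on the chain rather than removing heptyl, and it starts from the limit of > 50000 nM in this assay, at which 1 of the 3 values shown sits, so its size is only a floor. Without a number for compound 3, no size or direction can be expected for the step in this assay here. The nearest guide is compound 2 at 37900 nM as its chain also carries no hydroxy. Compound 4 is expected at about 30000 nM (estimated range 12000 nM to 55000 nM).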

Compound 4, half-maximal inhibitory concentration: 15900 nM
Estimate against measurement, compound 4: 1.9-fold (0.28 log units) above, within the range that was stated.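

In this assay, going by these compounds alone, the earlier compounds offered only a step whose floor lay within the scatter, and this result gives the first clear difference at this place on the chain. Methyl in place of hydrogen on a saturated chain carbon, eight bonds along the chain from an oxygen next to a carbonyl group, gives a 2.4-fold lower number from compound 2 to compound 4 (0.38 log units; beyond the scatter). Methyl in place of hydroxy at that same carbon gives an at least 3.1-fold lower number from compound 1 to compound 4 (0.49 log units; beyond the scatter), and that size is only a floor because compound 1 carries a limit and not a number: the limit of > 50000 nM in this assay, at which 1 of the 4 values shown sits.

Steps involving compound 3 cannot be read, as it has no reported result, so the effect of its longer chain stays open. From the compounds shown here alone, what an amine or a carboxylic acid on this carbon would give also stays open.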